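Swapping Trifluoromethyl for Chloro on an Inactive Quinolone Amide

The compounds below may be only part of what the source reports. "The series", "measured", "known", "first", "only" and "open" are said of these compounds alone.

Three amides built on one shared core have been tested in a functional assay on KYSE-410 cells (Homo sapiens) for antiproliferative activity, read by MTT assay, with a stated time of 72 h; a lower number here means a stronger inhibitor, a higher number a weaker inhibitor. Compound 1 `O=C(Nc1ccc(Cl)cc1)c1cc(=O)[nH]c2cc(Br)ccc12` carries a chloro group on its aniline ring, compound 2 `O=C(Nc1ccc(C(F)(F)F)cc1)c1cc(=O)[nH]c2cc(Br)ccc12` a trifluoromethyl group, and compound 3 `O=C(Nc1cccc(C(F)(F)F)c1)c1cc(=O)[nH]c2cc(Br)ccc12` the same trifluoromethyl group at a different position. In this assay compound 1 gives only a limit, > 20000 nM. Compound 2 likewise reaches no number in this assay and stops at the limit > 20000 nM. Compound 3 also shows only the limit > 20000 nM in this assay. Because all three sit at the limit of > 20000 nM in this assay, at which 3 of the 3 values shown sit, no potency can be compared among them.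

The change from compound 2 to compound 1 is chloro in place of trifluoromethyl on an aromatic carbon. Its size is a step that the two limits leave unreadable from compound 2 to compound 1. Compound 3 and compound 2 share the same atoms joined differently, and the difference between the two cores is not broken down here.

Compound 4 `O=C(Nc1cccc(Cl)c1)c1cc(=O)[nH]c2cc(Br)ccc12` is not yet measured. From compound 3 it differs by chloro in place of trifluoromethyl on an aromatic carbon. This is the same kind of change as that from compound 2 to compound 1, though there the chloro sits para to a large group and here it sits meta to a large group. Since compound 3 stands at > 20000 nM in this assay, and the same kind of change left compound 1 at the limit, the step from compound 3 to compound 4 is expected to be a step that the limit leaves unreadable from compound 3 to compound 4. Compound 4 is therefore estimated at 25000 nM in this assay, between 8000 nM and 60000 nM, most likely again only a limit.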

Compound 4, half-maximal inhibitory concentration: > 20000 nM
Compound 4: a limit, no number; the forecaster's own chance of this, stated with the estimate: 85%; the middle value does not contradict the limit.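

No new step can be read between compound 3 and compound 4, or between compound 1 and compound 4, because in this assay each of these compounds gives only a limit and no number: the limit of > 20000 nM in this assay, at which 4 of the 4 values shown sit.

The compounds shown leave open how chloro and trifluoromethyl, or their two ring positions, would compare in a compound on this shared core that gives a real number in this assay.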